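From Cyclopentyl to Arylsulfonyl on the Ring Amine Nitrogen

This account rests on a few compounds, and the source may have more. Where it says the series, first, only, none or still open, it means among the compounds named here.

Of the compounds shown here, three sharing one core have been measured in an assay on isolated protein for inhibition of 5-hydroxytryptamine receptor 4 (Homo sapiens); a higher number here means a weaker inhibitor, a lower number a stronger inhibitor. Compound 1 `O=C(NCC1CCN(CCCS(=O)(=O)N2CCN(c3ccccn3)CC2)CC1)c1cccc2c1OCCO2` gives 0.251 nM, compound 2 `O=C(NCC1CCN(CCCS(=O)(=O)N2CCNCC2)CC1)c1cccc2c1OCCO2` gives 0.159 nM, and compound 3 `O=C(NCC1CCN(CCCS(=O)(=O)N2CCN(C3CCCC3)CC2)CC1)c1cccc2c1OCCO2` gives 0.0159 nM. Compound 3 stands lowest of the three: the step of a 16-fold lower number from compound 1 to compound 3 (1.20 log units; beyond the scatter) and the step of a 10-fold lower number from compound 2 to compound 3 (1.00 log units; beyond the scatter) both lie beyond the scatter, so compound 3 is the strongest inhibitor among them, whereas a 1.6-fold lower number from compound 1 to compound 2 (0.20 log units; within the scatter) stays within the scatter.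

Compound 4 `O=C(NCC1CCN(CCCS(=O)(=O)N2CCN(S(=O)(=O)c3ccc(F)cc3)CC2)CC1)c1cccc2c1OCCO2` has not yet been measured. It differs from compound 3 in one place: (4-fluorophenyl)sulfonyl in place of cyclopentyl on an amine nitrogen in a ring. The two measured steps that end at compound 3 bear on this change, since each one swaps the group on that same ring nitrogen; in both the compound without the cyclopentyl gave the higher number, as seen in a 10-fold lower number from compound 2 to compound 3 (1.00 log units; beyond the scatter) and a 16-fold lower number from compound 1 to compound 3 (1.20 log units; beyond the scatter). Going by the values given here, no measured compound carries a sulfonyl on that nitrogen, so the size is uncertain, but an upward step in this assay of similar magnitude is expected, a 10-fold higher number from compound 3 to compound 4 (1.00 log units; beyond the scatter). For compound 4 the estimate is 0.16 nM, expected to fall between 0.03 nM and 0.8 nM.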

Compound 4, inhibition constant: 0.0316 nM
Compound 4: middle estimate off by 5.1-fold (0.70 log units), on the high side; the range from low to high includes it.
By their numbers in this assay, from the lowest: compounds 3 and 4 (each within the scatter of the next); then compounds 2 and 1 (each within the scatter of the next).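

Going by these compounds alone, on the ring amine nitrogen, (4-fluorophenyl)sulfonyl is the first sulfonyl group seen, and in this assay it stays within the scatter of cyclopentyl (a 2.0-fold higher number from compound 3 to compound 4 (0.30 log units; within the scatter)). It still keeps a clear edge over the other two groups (a 5.0-fold lower number from compound 2 to compound 4 (0.70 log units; beyond the scatter); a 7.9-fold lower number from compound 1 to compound 4 (0.90 log units; beyond the scatter)), so among these four compounds a low number at this nitrogen does not depend on cyclopentyl alone and extends to a group with a six-membered aromatic ring and two hydrogen-bond acceptors. Nothing available explains why these two groups give low numbers while pyridin-2-yl and hydrogen do not.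

The compounds shown leave open whether the fluorine or the sulfonyl matters here, a question that a phenylsulfonyl, a methylsulfonyl or an acetyl group on that nitrogen could address. As far as these compounds go, it also remains open how far the cyclopentyl result carries to a cyclohexyl or an isopropyl group.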